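Working notes: 3,4-dimethylphenyl to 2-chloro-4-methylphenyl

The source may hold more compounds than are shown below. What is called first, only, known or untested is meant among the compounds shown, and "the series" means these compounds.

In a functional assay on HepG2 cells (Homo sapiens) for antiproliferative activity, read by spectrophotometry, with a stated time of 2 days (a higher number here means a weaker inhibitor of growth, a lower number a stronger inhibitor of growth), compound 1 `CC(=O)N1CCN(c2ccc(Nc3ncc(C(F)(F)F)c(N4Cc5cccc(N(C)S(C)(=O)=O)c5C4)n3)cc2)CC1` gives 1400 nM and compound 3 `COc1cc(N2CCN(C(C)=O)CC2)ccc1Nc1ncc(C(F)(F)F)c(N2Cc3cccc(N(C)S(C)(=O)=O)c3C2)n1` gives 3800 nM.

Compound 2 `Cc1ccc(Nc2ncc(C(F)(F)F)c(N3Cc4cccc(N(C)S(C)(=O)=O)c4C3)n2)cc1C` stands apart from these two numbers, at the limit of > 30000 nM in this assay, at which 1 of the 3 values shown sits. Its result of > 30000 nM is a limit and not a number.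

Within the data shown here, compound 4 `Cc1ccc(Nc2ncc(C(F)(F)F)c(N3Cc4cccc(N(C)S(C)(=O)=O)c4C3)n2)c(Cl)c1` has no measurement yet. It differs from compound 2 as follows: 2-chloro-4-methylphenyl in place of 3,4-dimethylphenyl on a nitrogen on an aromatic ring. In words, this is 2-chloro-4-methylphenyl in place of 3,4-dimethylphenyl on a nitrogen on an aromatic ring.

Among the measured compounds shown here, the only measured step is a 2.7-fold higher number from compound 1 to compound 3 (0.43 log units; beyond the scatter), with methoxy in place of hydrogen on an aromatic carbon. That step is modest and is a different change, so it bears only loosely on this one. For the measured compounds named here, no measured step starts from compound 2.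

Going by the values given here, with that modest size as the sole guide, a small step in this assay is expected, with a slightly lower number as the tentative direction and no firm claim that it will exceed the scatter. The estimated step is an at least 1.2-fold lower number from compound 2 to compound 4 (0.07 log units; that floor lies within the scatter).

For compound 4 the expected value is 25000 nM, with an estimated range from 8000 nM to 60000 nM.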

Compound 4, concentration for 50% growth inhibition: > 30000 nM
Compound 4: only a limit was reported (the forecaster's own chance of this, stated with the estimate: 55%); at least 1.2-fold (0.07 log units) between middle value and limit.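

In this assay compound 4 gives > 30000 nM, which is a limit and not a number. Among these compounds, compound 2 gives > 30000 nM, also a limit, and no step to compound 4 can be read from the two. The compounds shown leave open whether 2-chloro-4-methylphenyl in place of 3,4-dimethylphenyl changes growth inhibition at all.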